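Cytotoxicity of pyrazine carboxamide series: chloro to pentylamino

The source may report more compounds than this note shows. Statements on the series, on what has been measured and on what is new or still open speak of the compounds shown alone.

Compound 2 `O=C(NCc1ccccc1)c1cncc(Cl)n1` has no result in an ADME assay on HEL cells (Homo sapiens) for cytotoxicity, read by microscopy, with a stated time of 6 days; on this read-out lower numbers stand for higher toxicity in this test and higher numbers for lower toxicity in this test; its entry reads "not determined" (no result reported). Among the numbers shown for the series there is therefore no number for compound 2 at all, only one further value, and that value is a limit rather than a number. Compound 1 `CCCCCCCCNc1cncc(C(=O)NCc2ccccc2)n1` gives > 100000 nM in this assay, which is a limit of the assay and not a measured number. Compound 3 `CCCCCNc1cncc(C(=O)NCc2ccccc2)n1` is the next member to be measured in this assay. It differs from compound 2 by pentylamino in place of chloro on an aromatic carbon. Compound 2 carries no number. Among the compounds with values here, the size and direction of the step from compound 2 to compound 3 cannot be put on a scale, and no step between measured compounds exists to calibrate it against. Compound 3 is expected to sit at 100000 nM, with a range from 30000 nM to 300000 nM, because the closest measured relative, compound 1, gives > 100000 nM and thereby sits at the limit of > 100000 nM in this assay, at which 1 of the 2 values shown sits. On these data alone, whether this assay reports a number or again only a limit for compound 3 remains open until the measurement is made.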

Compound 3, minimum cytotoxic concentration: > 100000 nM
Compound 3 ended at the assay's limit (the forecaster's own chance of this, stated with the estimate: 80%); the middle value sits exactly at the limit.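

No step can be read between compound 1 and compound 3 in this assay, since both entries are limits of the assay and not numbers: the limit of > 100000 nM in this assay, at which 2 of the 3 values shown sit.

The compounds shown leave open whether any amino chain on the shared core gives a readable number in this assay, and so whether chain length bears on this read-out.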